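Inverting One Ring Stereocentre in a Hydroxamic Acid Series

The source may hold more compounds than are shown below. What is called first, only, known or untested is meant among the compounds shown, and "the series" means these compounds.

Of the compounds shown here, three sharing one core have been measured in an assay on Sf9 cells for inhibition of histone deacetylase 11 (Homo sapiens), read by fluorescence, tested at 0.5 uM; a higher number here means more inhibition at the concentration tested (going by the name of the read-out), a lower number less inhibition. Compound 1 `O=C(/C=C/c1cn([C@H]2C[C@@H](CO)N(CCCc3ccccc3)C2)nn1)NO` gives 31% in this assay, compound 2 `O=C(/C=C/c1cn([C@H]2C[C@@H](CO)N(Cc3ccccc3)C2)nn1)NO` gives 35%, and compound 3 `O=C(/C=C/c1cn([C@H]2C[C@@H](C(=O)O)N(Cc3ccccc3)C2)nn1)NO` gives 23%. Compound 2 holds the highest of the three numbers; compound 1 lies nearest to it, within the scatter, and compound 3 lies furthest from it, beyond the scatter. The step of a number 4 percentage points higher from compound 1 to compound 2 (within the scatter) came with phenyl in place of phenethyl on a saturated chain carbon bound to an amine nitrogen in a ring, and the step of a number 12 percentage points lower from compound 2 to compound 3 (beyond the scatter) came with carboxy in place of hydroxymethyl on a saturated ring carbon.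

Compound 4 `O=C(/C=C/c1cn([C@H]2C[C@H](CO)N(Cc3ccccc3)C2)nn1)NO` differs from compound 2 as follows: the two compounds have the same atoms and bonds and differ only in configuration as drawn: 1 of 3 stereo elements differ; a stereocentre at a saturated ring carbon is drawn S in compound 2 and R in compound 4. Neither measured step involves a change of configuration, so the measured data give no direct guide to the size or direction of this step in this assay. Both measured steps, a number 4 percentage points higher from compound 1 to compound 2 (within the scatter) and a number 12 percentage points lower from compound 2 to compound 3 (beyond the scatter), were small or modest, so a change of similar magnitude, if any, seems the most reasonable expectation. The expected step is a number 9 percentage points lower from compound 2 to compound 4 (within the scatter). Compound 4 is therefore estimated to give 26% in this assay, with an expected range from 8% to 44%.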

Compound 4, a percentage reported as inhibition, at one concentration (the size of the read-out at that concentration, not a potency): 20%
Compound 4: middle estimate off by 6 percentage points, on the high side, and the stated range covers the measured number.
By their numbers in this assay, from the lowest: compounds 4, 3, 1 and 2 (each within the scatter of the next, the first and the last beyond it).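

In this assay, the stereocentre at this saturated ring carbon proves to be a position that matters on its own: a number 15 percentage points lower from compound 2 to compound 4 (beyond the scatter). For the compounds shown here, the earlier steps each exchanged one group for another, so they could not show that the read-out responds to configuration when the atoms and bonds stay the same, and this inversion with the benzyl-type substituent and hydroxymethyl group in place is the first step of that kind. Since nothing else separates the pair, the fall can be assigned to the change from S to R alone, and the support for that is this: the fact that compounds 2 and 4 differ only in the configuration as drawn.

The compounds shown leave open whether the same inversion would give a similar step in the series with phenethyl in place of phenyl or with carboxy in place of hydroxymethyl, and what inverting either of the other stereo elements would do. They also leave open whether a primary amine or a longer hydroxyalkyl chain on that ring carbon would keep this dependence on configuration, and, as every number comes from a single tested concentration, how the read-out would look as a potency.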